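The source may report more compounds than this note shows. Statements on the series, on what has been measured and on what is new or still open speak of the compounds shown alone.

Three compounds sharing one core were measured in a functional assay on MCF7 cells (Homo sapiens) for antiproliferative activity; on this read-out higher numbers stand for weaker inhibition and lower numbers for stronger inhibition. Compound 1 `C=CCCCn1c(Cc2cc(OC)c(OC)c(OC)c2)nc2c(N)nc(F)nc21` gives 44700 nM, compound 2 `CCCCCn1c(Cc2cc(OC)c(OC)c(OC)c2)nc2c(N)nc(F)nc21` gives 36300 nM, and compound 3 `CCCn1c(Cc2cc(OC)c(OC)c(OC)c2)nc2c(N)nc(F)nc21` gives 25100 nM. The steps among them, a 1.2-fold lower number from compound 1 to compound 2 (0.09 log units; within the scatter), a 1.8-fold lower number from compound 1 to compound 3 (0.25 log units; within the scatter) and a 1.4-fold lower number from compound 2 to compound 3 (0.16 log units; within the scatter), all fall within the scatter, so compound 3 holds the lowest of the three numbers without standing apart from the other two. Compound 4 `COCCn1c(Cc2cc(OC)c(OC)c(OC)c2)nc2c(N)nc(F)nc21` differs from compound 3 by methoxy in place of methyl on a saturated chain carbon, two bonds along the chain from an aromatic nitrogen. Among the compounds with values here, none of the measured steps touches this position; all three concern a saturated chain carbon three bonds along the chain from an aromatic nitrogen, and each stays within the scatter. On that basis the expected step in this assay is a 1.1-fold higher number from compound 3 to compound 4 (0.05 log units; within the scatter), nothing beyond the scatter. Compound 4 is therefore estimated at 28000 nM in this assay, with a range from 10000 nM to 80000 nM.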

Compound 4, half-maximal inhibitory concentration: 64600 nM
Beside the measured number, compound 4's estimate is 2.3-fold (0.36 log units) below it; the range from low to high includes it.
By their numbers in this assay, from the lowest: compounds 3, 2, 1 and 4 (each within the scatter of the next, the first and the last beyond it).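

In this assay, within the data shown here, methoxy in place of methyl at this position, on a saturated chain carbon two bonds along the chain from an aromatic nitrogen, gives a 2.6-fold higher number from compound 3 to compound 4 (0.41 log units; beyond the scatter), the only step beyond the scatter and one towards weaker inhibition. The same compound stays within the scatter of the other two, with a 1.8-fold higher number from compound 2 to compound 4 (0.25 log units; within the scatter) and a 1.4-fold higher number from compound 1 to compound 4 (0.16 log units; within the scatter), so the separation holds against compound 3 alone. Nothing available explains this step. From the compounds shown here alone, whether an amine or a carboxylic acid on this chain would track compound 3 or compound 4 remains open.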